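The source may hold more compounds than are shown below. What is called first, only, known or untested is meant among the compounds shown, and "the series" means these compounds.

Measured so far in an ADME assay on Caco-2 cells (Homo sapiens) for permeability, read by LC-MS, in the apical to basolateral direction, with a stated time of 60 min, at pH 6.5; a lower number here means that the compound crosses the layer more slowly, a higher number that the compound crosses the layer faster:
- compound 2 `Cc1cccc([C@@H](O)C(=O)N2N=CC[C@H]2C(=O)NCc2cc(Cl)ccc2-n2cnnn2)c1` gives 9.7 10^-6 cm/s
- compound 3 `O=C(NCc1cc(Cl)ccc1-n1cnnn1)[C@@H]1[C@H]2C[C@H]2CN1C(=O)[C@H](O)c1ccccc1` gives 12 10^-6 cm/s
- compound 1 `COC(C)(C)[C@@H](O)C(=O)N1[C@H](C(=O)NCc2cc(Cl)ccc2-n2cnnn2)C[C@@H]2C[C@@H]21` gives 16 10^-6 cm/s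

Compound 2 has the lowest of the three numbers; compound 3 is nearest and compound 1 furthest, yet both gaps lie within the scatter, so no ordering of the three can be read from these values. Compound 4 `CC(C)CC[C@@H](O)C(=O)N1N=CC[C@H]1C(=O)NCc1cc(Cl)ccc1-n1cnnn1` has not yet been measured in this assay. It differs from compound 2 in one place: isopentyl in place of 3-methylphenyl on a saturated chain carbon bound to a carbonyl carbon and an oxygen on a saturated carbon. Among the measured compounds shown here, no step between measured compounds isolates this kind of change, so the expectation rests on the spread of the three values alone, which all sit close together. Compound 4 is therefore expected to give a number in the same region, with any step from compound 2 expected to stay within the scatter rather than show a clear direction, and the estimated step is a 1.2-fold higher number from compound 2 to compound 4 (0.09 log units; within the scatter). For compound 4 the estimate in this assay is 12 10^-6 cm/s, expected to fall between 7 10^-6 cm/s and 20 10^-6 cm/s.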

Compound 4, apparent permeability: 29 10^-6 cm/s
Beside the measured number, compound 4's estimate is 2.4-fold (0.38 log units) below it, outside the stated range (above it).
By their numbers in this assay, from the lowest: compounds 2, 3, 1 and 4 (each within the scatter of the next, the first and the last beyond it).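

In this assay, isopentyl in place of 3-methylphenyl on a saturated chain carbon bound to a carbonyl carbon and an oxygen on a saturated carbon gives a 3.0-fold higher number from compound 2 to compound 4 (0.48 log units; beyond the scatter). Among the compounds shown here, the earlier compounds offered no pair differing in one place, so this is the first sign that the group at this position can move the number on the shared core beyond the scatter. No supporting measurement speaks to what underlies the step, which rests on a single pair.

On these data alone, whether the step follows from the loss of the aromatic ring or from the chain itself stays open, and cyclohexyl at this place would help separate the two. As far as these compounds go, how far the trend extends is also open, as a shorter chain such as ethyl or a chain ending in an amine could show.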